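The compounds below may be only part of what the source reports. "The series", "measured", "known", "first", "only" and "open" are said of these compounds alone.

Three compounds have so far been measured in a functional assay on HCT-116 cells (Homo sapiens) for cytotoxicity, read by MTT assay, with a stated time of 48 h, in the presence of a further agent that is not named here; a lower number here means that less compound is needed, a higher number that more compound is needed for the effect:

Compound 1, `CCCc1cc(NNC(=O)Nc2cc(Cl)nc(Cl)c2)nc2c1cnn2C`: 76200 nM
Compound 2, `COc1ccc(-c2cc(NNC(=O)Nc3cc(Cl)nc(OC)c3)nc3c2cnn3C)cc1`: 54200 nM
Compound 3, `COc1cc(NC(=O)NNc2cc(-c3ccc(F)cc3)c3cnn(C)c3n2)cc(Cl)n1`: 75300 nM

Compound 2 gives the lowest of the three numbers, yet it does not stand apart: the step of a 1.4-fold higher number from compound 2 to compound 3 (0.14 log units; within the scatter) is within the scatter, and compound 1 sits a comparable distance away, so the three values are indistinguishable.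

Compound 4, `COc1ccc(-c2cc(NNC(=O)Nc3cc(Cl)nc(Cl)c3)nc3c2cnn3C)cc1`, has not yet been measured. It differs from compound 2 by chloro in place of methoxy on an aromatic carbon. Going by the values given here, no single measured step bears directly on this exchange. Compound 1 carries the same 2,6-dichloropyridin-4-yl group as compound 4 and compound 2 the 2-chloro-6-methoxypyridin-4-yl group, but the two also differ elsewhere, and their values are within the scatter of each other. Among the compounds with values here, the only single step available, a 1.4-fold higher number from compound 2 to compound 3 (0.14 log units; within the scatter), concerns the other ring and is likewise within the scatter. Nothing in these data therefore points to a step beyond the scatter in this assay.

Compound 4 is accordingly expected to give about 65000 nM, with a range from 30000 nM to 140000 nM. The expected step is a 1.2-fold higher number from compound 2 to compound 4 (0.08 log units; within the scatter), no change beyond the scatter.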

Compound 4, half-maximal effective concentration: 12300 nM
Compound 4: the middle estimate sits 5.3-fold (0.72 log units) above what was measured; the measured number lies below the stated range.
By their numbers in this assay, from the lowest: compound 4; then compounds 2, 3 and 1 (each within the scatter of the next).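

In this assay, the position next to the ring nitrogen now proves able to move the number: chloro in place of methoxy gives a 4.4-fold lower number from compound 2 to compound 4 (0.64 log units; beyond the scatter), a step that the earlier compounds could not have shown. The group on the shared core also matters when the 2,6-dichloropyridin-4-yl group is held fixed, since 4-methoxyphenyl in place of propyl gives a 6.2-fold lower number from compound 1 to compound 4 (0.79 log units; beyond the scatter), and compound 4 is the only compound shown that carries both of these groups. Nothing available explains either step.

The compounds shown leave open whether the same exchange would give a similar step with the 4-fluorophenyl group of compound 3. They also leave open how a bromo group or an amine would behave at this position.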